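Compound 3: A New Phenoxy Group on the Shared Core

The source may report more compounds than this note shows. Statements on the series, on what has been measured and on what is new or still open speak of the compounds shown alone.

In a functional assay on MCF7 cells (Homo sapiens) for antiproliferative activity, read by MTT assay, with a stated time of 48 h (on this read-out higher numbers stand for weaker inhibition and lower numbers for stronger inhibition), compound 1 `O=c1cc(-n2cc(CNc3ccccc3)nn2)c2cc(Br)ccc2o1` gives only a limit of the assay, > 50000 nM. Among the compounds with values here, compound 2 `O=c1cc(-n2cc(COc3ccccc3Br)nn2)c2cc(Br)ccc2o1` gives 28900 nM, the sole exact number so far. Compound 3 `CCc1ccc(OCc2cn(-c3cc(=O)oc4ccc(Br)cc34)nn2)cc1` differs from it by 4-ethylphenyl in place of 2-bromophenyl on an oxygen on a saturated carbon, with 4-ethylphenyl in place of 2-bromophenyl on an oxygen on a saturated carbon. Within the data shown here, the one measured step, an at least 1.7-fold lower number from compound 1 to compound 2 (0.23 log units; that floor lies within the scatter), concerns a different exchange and has a floor within the scatter, so no change beyond the scatter is expected in this assay. The expected step is a 1.0-fold higher number from compound 2 to compound 3 (0.02 log units; within the scatter). Compound 3 is estimated at 30000 nM, within an expected range of 13000 nM to 50000 nM.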

Compound 3, half-maximal inhibitory concentration: 12700 nM
Estimate against measurement, compound 3: 2.4-fold (0.37 log units) above; measured number outside the range, below it.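

In this assay, within the data shown here, this position answers the exchange of 2-bromophenyl for 4-ethylphenyl with a 2.3-fold lower number from compound 2 to compound 3 (0.36 log units; beyond the scatter) and so gives a change beyond the scatter, which the one earlier step did not. Against the anilino group, 4-ethylphenoxy gives an at least 3.9-fold lower number from compound 1 to compound 3 (0.59 log units; beyond the scatter) and is the first group to clear the scatter from compound 1. Compound 1 stands at a limit of the assay, so that step is only a floor: the limit of > 50000 nM in this assay, at which 1 of the 3 values shown sits. The compounds shown leave open whether the ethyl or the lost bromine carries the step. They also leave open how a longer chain or an amine in place of the ethyl would read.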